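Swapping the aryl group on the furan-bearing ester

The source may report more compounds than this note shows. Statements on the series, on what has been measured and on what is new or still open speak of the compounds shown alone.

Measured so far:
compound 1 `COc1cc(C(=O)OCc2ccc(-c3ccc(Cl)cc3Cl)o2)cc(OC)c1OC` gives 24.4%;
compound 2 `CCOc1cc(C(=O)OCc2ccc(-c3ccc(Cl)cc3Cl)o2)cc(OCC)c1OCC` gives 3.7%;
compound 3 `COc1cc(COC(=O)c2ccc(-c3ccccc3C(F)(F)F)o2)cc(OC)c1OC` gives 54.9%.

In an assay on isolated protein for inhibition of high affinity 3',5'-cyclic-AMP phosphodiesterase 7A (Homo sapiens), read by scintillation proximity assay and cAMP accumulation, with a stated time of 20 min, tested at 10 uM (a lower number here means less inhibition, a higher number more inhibition at the concentration tested (going by the name of the read-out)), compound 3 stands highest of the three numbers. Its nearest neighbour is compound 1, whose number lies well beyond the usual scatter below it, and compound 2 lies further still, also beyond the scatter. Compound 4 `COc1ccc(-c2ccc(C(=O)OCc3cc(OC)c(OC)c(OC)c3)o2)cc1` has not yet been measured. It differs from compound 3 in one place: 4-methoxyphenyl in place of 2-(trifluoromethyl)phenyl on an aromatic carbon. For the measured compounds named here, no pair of measured compounds differs in just this group, so the weight of this change has not been seen directly; only the numbers of compounds 1, 2 and 3, which differ in several places at once, are available. On that thin basis a downward step from compound 3 to compound 4 is expected, of a size that may or may not exceed the scatter: a number 19.9 percentage points lower from compound 3 to compound 4 (beyond the scatter). Compound 4 is therefore estimated at 35% in this assay, within a range of 10% to 60%.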

Compound 4, a percentage reported as inhibition, at one concentration (the size of the read-out at that concentration, not a potency): 14%
Estimate against measurement, compound 4: 21 percentage points above; low and high end bracket the measured number.
By their numbers in this assay, from the lowest: compound 2; then compound 4; then compound 1; then compound 3.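

In this assay, putting 4-methoxyphenyl in place of 2-(trifluoromethyl)phenyl on the aromatic carbon next to the ring oxygen gives a number 40.9 percentage points lower from compound 3 to compound 4 (beyond the scatter). For the compounds shown here, this is the first direct view of this position, with the rest of the molecule unchanged, and it shows that the group held here can alter the inhibition seen at the tested concentration by a large amount. Nothing measured here gives a reason for the step.

Going by these compounds alone, with only this pair, the loss of the trifluoromethyl, the gain of the methoxy and the different place of each group on the phenyl ring cannot be told apart. A plain phenyl carrying neither group, or a phenyl carrying an amine, would give further points of comparison at this position.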